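The source may hold more compounds than are shown below. What is called first, only, known or untested is meant among the compounds shown, and "the series" means these compounds.

Compound 1 `CCN(CC)CCn1cnnc1-c1cc(Oc2ccc(NC(=O)Nc3ccc(F)c(Cl)c3)cc2F)ccn1` gives 7390 nM in a functional assay on NCI-H460 cells (Homo sapiens) for antiproliferative activity, read by MTT assay, with a stated time of 72 h; a higher number here means a weaker inhibitor, a lower number a stronger inhibitor.
Compound 2 `CN(C)CCCn1cnnc1-c1cc(Oc2ccc(NC(=O)Nc3ccc(Cl)c(C(F)(F)F)c3)cc2F)ccn1` gives 1680 nM in this assay.
Compound 3 `CN(C)CCCn1cnnc1-c1cc(Oc2ccc(NC(=O)Nc3ccccc3C(F)(F)F)cc2F)ccn1` gives 10900 nM in this assay.

Compound 3 has the highest number of the three, which means it is the weakest inhibitor among them. Its nearest neighbour is compound 1, whose number is within the scatter of that of compound 3; the value of compound 2 lies well beyond the scatter, as the step of a 6.5-fold higher number from compound 2 to compound 3 (0.81 log units; beyond the scatter) shows.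

Compound 4 `CN(C)CCCn1cnnc1-c1cc(Oc2ccc(NC(=O)Nc3ccc(F)c(Cl)c3)cc2F)ccn1` has not yet been measured. It differs from compound 3 in one place: 3-chloro-4-fluorophenyl in place of 2-(trifluoromethyl)phenyl on an amide-type nitrogen. Within the data shown here, the only measured step that bears on this kind of change is a 6.5-fold higher number from compound 2 to compound 3 (0.81 log units; beyond the scatter), where moving the substituents on that ring raised the number by a modest amount. Compound 4 reverses a change of that sort, so a modest drop in number is expected, a 2.2-fold lower number from compound 3 to compound 4 (0.34 log units; beyond the scatter). Compound 4 carries the same aryl group as compound 1, and compound 1 gives 7390 nM, which supports a value in that region. Compound 4 is therefore estimated at 5000 nM, likely between 2000 nM and 14000 nM.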

Compound 4, half-maximal inhibitory concentration: 1270 nM
Beside the measured number, compound 4's estimate is 3.9-fold (0.60 log units) above it; measured number below the stated range.
By their numbers in this assay, from the lowest: compounds 4 and 2 (each within the scatter of the next); then compounds 1 and 3 (each within the scatter of the next).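

Changing the group on the amide-type nitrogen to 3-chloro-4-fluorophenyl in place of 2-(trifluoromethyl)phenyl gives an 8.6-fold lower number from compound 3 to compound 4 (0.93 log units; beyond the scatter) in this assay, whereas replacing 4-chloro-3-(trifluoromethyl)phenyl with it gives a 1.3-fold lower number from compound 2 to compound 4 (0.12 log units; within the scatter), so these two different aryl groups cannot be told apart here. With the aryl group held constant, (dimethylamino)methyl in place of diethylamino on the saturated chain gives a 5.8-fold lower number from compound 1 to compound 4 (0.76 log units; beyond the scatter), the first sign that the chain end also affects the number. No measurement shown accounts for either difference.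

On these data alone, whether a 3-(trifluoromethyl)phenyl or an unsubstituted phenyl on the amide-type nitrogen would match compound 4 remains open. So does the effect of a morpholine or a pyrrolidine at the end of the chain.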